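The compounds below may be only part of what the source reports. "The series", "measured", "known", "first", "only" and "open" are said of these compounds alone.

Measured so far in the series:
compound 1, `N#C/C(=C\c1c(-c2ccccc2)[nH]c2ccccc12)C(=O)Nc1ccc(Cl)cc1`, 1700 nM
compound 2, `N#C/C(=C\c1c(-c2ccccc2)[nH]c2ccccc12)C(N)=O`, 6000 nM
compound 3, `N#C/C(=C\c1c(-c2ccccc2)[nH]c2ccccc12)C(=O)c1cccs1`, 400 nM

In a functional assay on MT4 cells (Homo sapiens) for antiproliferative activity, read by MTT assay, with a stated time of 96 h (on this read-out higher numbers stand for an effect only at larger amounts of compound and lower numbers for an effect already at smaller amounts), compound 3 stands lowest of the three numbers: the step of a 4.3-fold lower number from compound 1 to compound 3 (0.63 log units; beyond the scatter) and the step of a 15-fold lower number from compound 2 to compound 3 (1.18 log units; beyond the scatter) are both beyond the scatter, so compound 3 is the most potent compound measured on this assay. The step of a 3.5-fold higher number from compound 1 to compound 2 (0.55 log units; beyond the scatter) shows that, among the two compounds carrying a nitrogen on the carbonyl carbon, the substituted one gives the lower number.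

The next compound, compound 4 `COCCOC(=O)/C(C#N)=C/c1c(-c2ccccc2)[nH]c2ccccc12`, differs from compound 3 by 2-methoxyethoxy in place of thiophen-2-yl on a carbonyl carbon. Going by the values given here, no measured pair covers an alkoxy group on this carbonyl carbon. Among the compounds with values here, the steps that bear on it are those into compound 3, a 4.3-fold lower number from compound 1 to compound 3 (0.63 log units; beyond the scatter) and a 15-fold lower number from compound 2 to compound 3 (1.18 log units; beyond the scatter): each time the thiophen-2-yl group took the place of a nitrogen-bearing group the number fell, modestly in one case and largely in the other. Leaving the thiophen-2-yl group again, now for an oxygen-bearing chain, is therefore expected to raise the number in this assay by a modest step, a 4.5-fold higher number from compound 3 to compound 4 (0.65 log units; beyond the scatter). Compound 4 is estimated at 1800 nM, within a range from 550 nM to 6000 nM.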

Compound 4, half-maximal effective concentration: 1200 nM
For compound 4 the middle estimate is 1.5-fold (0.18 log units) above the measured one; measured number inside the range.
By their numbers in this assay, from the lowest: compound 3; then compounds 4 and 1 (each within the scatter of the next); then compound 2.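

In this assay, a 3.0-fold higher number from compound 3 to compound 4 (0.48 log units; beyond the scatter) shows that on this carbonyl carbon a ring-free 2-methoxyethoxy chain does not match thiophen-2-yl, so the step away from thiophen-2-yl raises the number with an oxygen-bearing group as it did with the nitrogen-bearing ones. At the same time, a 5.0-fold lower number from compound 2 to compound 4 (0.70 log units; beyond the scatter) shows that a group without a ring need not end at the high number of the plain amino compound, while a 1.4-fold lower number from compound 1 to compound 4 (0.15 log units; within the scatter) lies within the scatter, so 2-methoxyethoxy and (4-chlorophenyl)amino cannot be told apart here, even though only the latter carries a ring. No supporting data are at hand to explain any of these steps.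

The compounds shown leave open whether the low number of compound 3 belongs to thiophen-2-yl itself or would also come with another aromatic ring on the carbonyl carbon, such as furan-2-yl or phenyl. They also leave open how much of the 2-methoxyethoxy result depends on the chain, which a plain ethoxy group, a longer ether chain or a free carboxylic acid at this place would test.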